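From ethyl to (thiophen-2-yl)sulfonyl in a cell growth assay

This account rests on a few compounds, and the source may have more. Where it says the series, first, only, none or still open, it means among the compounds named here.

Measured in a functional assay on HeLa cells (Homo sapiens) for antiproliferative activity, read by MTT assay, with a stated time of 48 h (on this read-out higher numbers stand for weaker inhibition and lower numbers for stronger inhibition), so far:
compound 1 `Cn1cc(-c2cnc3ccc(NS(=O)(=O)c4cccs4)nc3c2)cn1` gives 38400 nM
compound 2 `CCNc1nccc2ncc(-c3cnn(C)c3)cc12` gives > 50000 nM (a limit, not a number)

Compound 2 stands at the limit of > 50000 nM in this assay, at which 1 of the 2 values shown sits, and so offers a limit, not a number, as the starting point. Compound 3 `Cn1cc(-c2cnc3ccnc(NS(=O)(=O)c4cccs4)c3c2)cn1` has (thiophen-2-yl)sulfonyl in place of ethyl on a nitrogen on an aromatic ring. Among the measured compounds shown here, no measured step shows what this change does. For the measured compounds named here, the only guide is compound 1, which also carries (thiophen-2-yl)sulfonyl and gives 38400 nM in this assay as a weak result. Resting on compound 1 at 38400 nM as a guide, only a small move toward stronger inhibition is expected, perhaps none beyond the usual scatter. The estimate means an at least 1.6-fold lower number from compound 2 to compound 3 (0.22 log units; that floor lies within the scatter) in this assay as the expected step. Compound 3 is expected at 30000 nM in this assay, with an estimated range from 10000 nM to 70000 nM as its likely span.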

Compound 3, half-maximal inhibitory concentration: 17400 nM
The estimate for compound 3 lay 1.7-fold (0.24 log units) above the measured number, within the range that was stated.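

Among the compounds shown here, until now, no measured pair showed what happens on this nitrogen on an aromatic ring when ethyl gives way to (thiophen-2-yl)sulfonyl. In this assay the change gives an at least 2.8-fold lower number from compound 2 to compound 3 (0.45 log units; beyond the scatter), so this position accepts the sulfonyl group and the swap goes with stronger inhibition, although compound 3, at 17400 nM, is still a weak result. That step is only a floor, and its true size stays unknown, because compound 2 gives a limit and not a number: the limit of > 50000 nM in this assay, at which 1 of the 3 values shown sits.

The sulfonyl and the thiophene ring enter together, so the compounds shown do not tell which of the two goes with the stronger inhibition. Also open, on these data alone, is how a methylsulfonyl or phenylsulfonyl group on the same nitrogen would compare.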